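Methylating the ring amine of compound 2

The compounds below may be only part of what the source reports. "The series", "measured", "known", "first", "only" and "open" are said of these compounds alone.

Going by the values given here, compound 2 `COCC[C@H]1C[C@@H]1c1cncc(N2CCCNCC2)c1` is measured in an assay on a protein complex for displacement of a labelled ligand from Neuronal acetylcholine receptor; alpha3/beta2 (Rattus norvegicus), read by scintillation counting (a lower number here means a stronger inhibitor, a higher number a weaker inhibitor), at 17 nM; of the three numbers known it is the second highest, with compound 3 `COCC[C@@H]1C[C@H]1c1cncc(N2CCCNCC2)c1` at 15.8 nM closest and compound 1 `COCC[C@H]1C[C@@H]1c1cncc(N2C[C@@H]3C[C@H]2CN3)c1` at 141 nM furthest. Compound 3 is the mirror image of compound 2, and the step of a 1.1-fold lower number from compound 2 to compound 3 (0.03 log units; within the scatter) shows the two measurements sit together, because the fact that compounds 2 and 3 differ only in the configuration as drawn the pair differs only in configuration as drawn.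

Compound 4 `COCC[C@H]1C[C@@H]1c1cncc(N2CCCN(C)CC2)c1` is not yet measured. It differs from compound 2 by methyl in place of hydrogen on an amine nitrogen in a ring. Among the compounds with values here, no measured step touches the ring amine: the only step known, the one from compound 2 to compound 3, concerns configuration alone and gives no guidance on substitution of that nitrogen. Compound 1 carries a different bicyclic amine and is not a one-place change from compound 2, so its value is noted but not used as a step.

With nothing comparable in hand, a modest rise in number beyond the scatter is the expectation for compound 4, an estimated 40 nM within 12 nM to 150 nM. The expected step is a 2.4-fold higher number from compound 2 to compound 4 (0.37 log units; beyond the scatter).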

Compound 4, inhibition constant: 681 nM
For compound 4 the middle estimate is 17-fold (1.23 log units) below the measured one; the whole stated range lies below it.
By their numbers in this assay, from the lowest: compounds 3 and 2 (each within the scatter of the next); then compound 1; then compound 4.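

In this assay methyl in place of hydrogen on the amine nitrogen in the ring gives a 40-fold higher number from compound 2 to compound 4 (1.60 log units; beyond the scatter) and so marks this nitrogen as a place where the number responds strongly to a single added carbon. Going by these compounds alone, the only earlier one-place step, a 1.1-fold lower number from compound 2 to compound 3 (0.03 log units; within the scatter) and limited to configuration, gave no sign of such sensitivity. Nothing at hand bears on why this methyl has so large an effect.

As far as these compounds go, whether the rise belongs to methyl alone or to any group on this nitrogen stays open, and an ethyl group, an acetyl group or a longer chain there would help separate the two. Also open, from the compounds shown here alone, is whether the mirror-image forms still give matching numbers once the ring nitrogen carries methyl.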